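This account rests on a few compounds, and the source may have more. Where it says the series, first, only, none or still open, it means among the compounds named here.

Measured so far in a functional assay on PANC-1 cells (Homo sapiens) for inhibition, read by MTT assay, with a stated time of 24 h; on this read-out higher numbers stand for weaker inhibition and lower numbers for stronger inhibition:
compound 1, `CC1(C)[C@H]2CC[C@]1(C)N(Cc1cn(-c3cccc(Cl)c3)nn1)C(=O)C2`, 260 nM;
compound 2, `Cc1ccccc1-n1cc(CN2C(=O)C[C@@H]3CC[C@@]2(C)C3(C)C)nn1`, 250 nM;
compound 3, `Cc1ccc(-n2cc(CN3C(=O)C[C@@H]4CC[C@@]3(C)C4(C)C)nn2)cc1`, 270 nM.

Compound 3 has the highest of the three numbers, but its gaps to compound 1 and compound 2 are within the scatter, so the three stand level. Compound 4, `CC1(C)[C@H]2CC[C@]1(C)N(Cc1cn(-c3ccc(F)cc3)nn1)C(=O)C2`, differs from compound 3 by fluoro in place of methyl on an aromatic carbon. All three measured steps change the group on the aromatic nitrogen: a 1.0-fold lower number from compound 1 to compound 2 (0.02 log units; within the scatter), a 1.0-fold higher number from compound 1 to compound 3 (0.02 log units; within the scatter) and a 1.1-fold higher number from compound 2 to compound 3 (0.03 log units; within the scatter), each within the scatter. None of them exchanges a methyl for a fluoro, so they bear only loosely on this step, yet they show that changing the aryl group left the number unmoved. The step is therefore expected to be no change at the digits printed from compound 3 to compound 4 (within the scatter), none beyond the scatter. Compound 4 is estimated at 270 nM, with a range from 140 nM to 540 nM.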

Compound 4, half-maximal inhibitory concentration: 110 nM
The estimate for compound 4 lay 2.5-fold (0.39 log units) above the measured number, and the stated range ends above it.
By their numbers in this assay, from the lowest: compound 4; then compounds 2, 1 and 3 (each within the scatter of the next).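

this assay shows a 2.5-fold lower number from compound 3 to compound 4 (0.39 log units; beyond the scatter) when fluoro replaces methyl, the first step beyond the scatter at this aryl group. The 4-fluorophenyl group also gives a 2.3-fold lower number from compound 2 to compound 4 (0.36 log units; beyond the scatter) and a 2.4-fold lower number from compound 1 to compound 4 (0.37 log units; beyond the scatter) in comparison with the other aryl groups, so this part of the molecule can change the number after all. No measurement shown accounts for this drop.

As far as these compounds go, whether fluoro is needed for the lower number stays open. A chloro, a methoxy or an amine on the same aromatic carbon, para to a large group, would help to test this.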